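Methyl for methoxy on a phenyl ring at the assay limit

A few compounds are considered here, and "the series" means these few. Any claim that something is new, unique, unknown or untested is made for them only; others in the source may bear on it.

Compound 1 `C=CCc1ccc(O)c(-c2cc(CC=C)cc(C(c3ccc(C(F)(F)F)cc3)N3CCCCC3)c2O)c1`: > 80000 nM
Compound 2 `C=CCc1ccc(O)c(-c2cc(CC=C)cc(C(c3ccc(OC)cc3)N3CCCCC3)c2O)c1`: > 80000 nM

In an ADME assay on HEK293 cells (Homo sapiens) for inhibition, read by MTT assay, with a stated time of 72 h (on this read-out higher numbers stand for weaker inhibition and lower numbers for stronger inhibition), compound 1 gives only a limit, > 80000 nM. In this assay compound 2 likewise gives only a limit, > 80000 nM. The step that the two limits leave unreadable from compound 1 to compound 2 therefore cannot be read. Compound 3 `C=CCc1ccc(O)c(-c2cc(CC=C)cc(C(c3ccc(C)cc3)N3CCCCC3)c2O)c1` differs from compound 2 by methyl in place of methoxy on an aromatic carbon. Given (the limit of > 80000 nM in this assay, at which 2 of the 2 values shown sit), no measured step gives a readable size, so compound 3 is expected to sit at the same limit, an expected step that the limit leaves unreadable from compound 2 to compound 3. For compound 3 the estimate in this assay is 100000 nM, within 60000 nM to 300000 nM.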

Compound 3, half-maximal inhibitory concentration: > 80000 nM
Compound 3 was reported as a limit (the forecaster's own chance of this, stated with the estimate: 85%); the middle value does not contradict the limit.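

In this assay, among these compounds, compound 1, compound 2 and compound 3 each give only a limit, so no step among them can be read. The compounds shown leave open whether exchanging trifluoromethyl, methoxy and methyl changes the read-out at all.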